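This account rests on a few compounds, and the source may have more. Where it says the series, first, only, none or still open, it means among the compounds named here.

Working notes on the series. Compound 3 `CCCCCCCN(CCCCCSc1nc(O)c2ccccc2n1)C(=O)Nc1ccc(F)cc1F` is the reference for the next step. In an assay on microsomes from liver for inhibition of sterol O-acyltransferase 1 (Rattus norvegicus) (on this read-out higher numbers stand for weaker inhibition and lower numbers for stronger inhibition), compound 3 gives 4000 nM. Compound 1 `CCCCCCN(CCCCCSc1nc2ccccc2s1)C(=O)Nc1ccc(F)cc1F` gives 4000 nM in this assay, the same number at the digits recorded, so compounds 1 and 3 together hold the highest numbers of the three measured. Within the data shown here, compound 2 `CCCCCCN(CCCCCSc1nc2cc([N+](=O)[O-])ccc2[nH]1)C(=O)Nc1ccc(F)cc1F` gives 2000 nM in this assay; the step of a 2.0-fold lower number from compound 1 to compound 2 (0.30 log units; within the scatter) is the only single-point step measured so far, and it stays within the scatter. Among the measured compounds shown here, the difference between compound 3 and compound 2 is likewise within the scatter, and no single-point step connects them.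

Compound 4 `CCCCCCCN(CCCCCSc1[nH]cnc2ncnc1-2)C(=O)Nc1ccc(F)cc1F` has not yet been measured. It differs from compound 3 in one place: a group of 9 heavy atoms (5 carbon, 4 nitrogen; one five-membered aromatic ring with 2 hetero atoms, one six-membered aromatic ring with 2 hetero atoms) in place of a group of 11 heavy atoms (8 carbon, 2 nitrogen, 1 oxygen; one six-membered aromatic ring of carbon only, one six-membered aromatic ring with 2 hetero atoms), on a sulfur. For the measured compounds named here, the only measured step that bears on an exchange of the heteroaryl group on the sulfur is a 2.0-fold lower number from compound 1 to compound 2 (0.30 log units; within the scatter), which stayed within the scatter. On that basis the exchange in compound 4 is expected to move the number in this assay by no more than the scatter, in no particular direction. For compound 4 the expected step is no change at the digits printed from compound 3 to compound 4 (within the scatter), none beyond the scatter. The estimate for compound 4 in this assay is 4000 nM, with a range from 1300 nM to 12000 nM.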

Compound 4, half-maximal inhibitory concentration: 200 nM
For compound 4 the middle estimate is 20-fold (1.30 log units) above the measured one; measured number below the stated range.
By their numbers in this assay, from the lowest: compound 4; then compounds 2, 1 and 3 (each within the scatter of the next).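

In this assay, among these compounds, the heteroaryl group on the sulfur can move the number well beyond the scatter: replacing 4-hydroxyquinazolin-2-yl with the group of a five-membered and a six-membered aromatic ring gives a 20-fold lower number from compound 3 to compound 4 (1.30 log units; beyond the scatter), whereas the only earlier step at this place, a 2.0-fold lower number from compound 1 to compound 2 (0.30 log units; within the scatter), stayed within the scatter. The exchange therefore shows that this place is sensitive to the identity of the group, even though the leaving and entering groups have the same hydrogen-bond donor and acceptor counts and no net charge, so those counts do not separate them. No measurement at hand accounts for the large step.

Among the compounds shown here, the single step cannot show which difference between the two groups carries the change, whether the loss of the carbon-only ring, the presence of the five-membered ring or the different nitrogen content. It also leaves open whether a single-ring pyridin-2-yl on the sulfur, or an amine or a carboxylic acid on the entering group, would keep the lower number.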